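Swapping a Dihydroxyphenyl Ring for a Hydroxycyclohexyl Ring

This account rests on a few compounds, and the source may have more. Where it says the series, first, only, none or still open, it means among the compounds named here.

Of the compounds shown here, three have been tested in a functional assay on RS4-11 cells (Homo sapiens) for inhibition, read by CCK-8 assay, with a stated time of 48 h; on this read-out lower numbers stand for stronger inhibition and higher numbers for weaker inhibition. Compound 1 `O=[N+]([O-])c1ccc(NC(=S)NCCNS(=O)(=O)c2ccc(-c3ccccc3O[C@H]3CC[C@@H](O)CC3)s2)cc1` gives 9400 nM, compound 2 `O=C(NCCNS(=O)(=O)c1ccc(-c2ccccc2Oc2ccc(O)c(O)c2)s1)Nc1cc(Cl)cc(Cl)c1` gives 4500 nM, and compound 3 `O=C(NCCNS(=O)(=O)c1cc(-c2ccccc2Oc2ccc(O)c(O)c2)cs1)Nc1cc(C(F)(F)F)cc(C(F)(F)F)c1` gives 3900 nM. Compound 2 stands second highest of the three; its number and that of compound 3 lie within the scatter of each other, whereas compound 1 sits beyond the scatter on the higher side.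

The unmeasured compound 4 `O=C(NCCNS(=O)(=O)c1ccc(-c2ccccc2O[C@H]2CC[C@H](O)CC2)s1)Nc1cc(Cl)cc(Cl)c1` differs from compound 2 in one place: 4-hydroxycyclohexyl in place of 3,4-dihydroxyphenyl on an oxygen on an aromatic ring. For the measured compounds named here, no measured pair shows this change alone. Compound 1 carries the same entering group but differs elsewhere too, so its number is only a loose hint. In this assay a modest move toward a higher number is expected, a 1.6-fold higher number from compound 2 to compound 4 (0.19 log units; within the scatter). Compound 4 is therefore estimated at 7000 nM, between 2500 nM and 20000 nM.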

Compound 4, half-maximal inhibitory concentration: 14100 nM
Estimate against measurement, compound 4: 2.0-fold (0.30 log units) below; the measured number falls inside the stated range.
By their numbers in this assay, from the lowest: compounds 3 and 2 (each within the scatter of the next); then compounds 1 and 4 (each within the scatter of the next).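

In this assay replacing 3,4-dihydroxyphenyl with 4-hydroxycyclohexyl on this oxygen gives a 3.1-fold higher number from compound 2 to compound 4 (0.50 log units; beyond the scatter) with the rest of the structure unchanged. For the compounds shown here, this is the first view of the change on its own, and it shows that inhibition at this position weakens when the aromatic ring gives way to the non-aromatic one. No available measurement explains why the number rises.

Still open, going by these compounds, is whether a phenyl ring with a single hydroxyl, or a cyclohexyl ring carrying an amine or a carboxylic acid instead of the hydroxyl, would stay closer to compound 2. The same swap on the core of compound 3 also remains to be seen.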